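The source may hold more compounds than are shown below. What is called first, only, known or untested is meant among the compounds shown, and "the series" means these compounds.

In a functional assay on Jurkat cells (Homo sapiens) for cytotoxicity, read by MTT assay, with a stated time of 72 h (a lower number here means a stronger inhibitor, a higher number a weaker inhibitor), three compounds have been measured so far. Compound 1 `O=C(Nc1ccccc1)Nc1ccc(C(=O)NO)cc1` gives 2500 nM, compound 2 `O=C(/C=C/c1ccc(NC(=O)Nc2ccccc2)cc1)NO` gives 160 nM, and compound 3 `O=C(/C=C/c1ccc(NC(=O)Nc2ccc([N+](=O)[O-])cc2)cc1)NO` gives 90 nM. Compound 2 therefore sits well under compound 1, and within the usual scatter of compound 3.

Compound 4 `O=C(CCc1ccc(NC(=O)Nc2ccccc2)cc1)NO` has not yet been measured. It differs from compound 2 in one place: 2-(hydroxycarbamoyl)ethyl in place of 2-(hydroxycarbamoyl)ethenyl on an aromatic carbon. In words, 2-(hydroxycarbamoyl)ethyl stands in place of 2-(hydroxycarbamoyl)ethenyl on an aromatic carbon, para to a large group.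

Two measured steps offer guidance, though neither tests this exact change. The first is large: a 16-fold lower number from compound 1 to compound 2 (1.19 log units; beyond the scatter), with 2-(hydroxycarbamoyl)ethenyl replacing hydroxycarbamoyl. It shows that the group at this site can matter greatly. The second is a 1.8-fold lower number from compound 2 to compound 3 (0.25 log units; within the scatter), with nitro replacing hydrogen. It lies within the scatter and says little about the chain.

Compound 4 keeps an extended chain, so a full return to the level of compound 1 at 2500 nM is not expected, but part of the gain could be lost. The expected change is modest and towards a weaker result, an estimated 2.0-fold higher number from compound 2 to compound 4 (0.30 log units; within the scatter). For compound 4 the estimated value is 320 nM, with an expected range of 120 nM to 900 nM.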

Compound 4, half-maximal inhibitory concentration: 1590 nM
Beside the measured number, compound 4's estimate is 5.0-fold (0.70 log units) below it, and the stated range ends below it.
By their numbers in this assay, from the lowest: compounds 3 and 2 (each within the scatter of the next); then compounds 4 and 1 (each within the scatter of the next).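

In this assay, the step of a 9.9-fold higher number from compound 2 to compound 4 (1.00 log units; beyond the scatter) shows that chain length alone does not set the number at this position, since 2-(hydroxycarbamoyl)ethyl and 2-(hydroxycarbamoyl)ethenyl hold the same heavy atoms and differ only in having 1 rather than 2 double bonds outside aromatic rings. The step of a 1.6-fold lower number from compound 1 to compound 4 (0.20 log units; within the scatter) then places the saturated chain level with hydroxycarbamoyl set directly on the aromatic carbon, so among these compounds the large step of a 16-fold lower number from compound 1 to compound 2 (1.19 log units; beyond the scatter) is seen only with the ethenyl chain. Nothing measured here explains why removing this double bond matters so much.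

Going by these compounds, what remains open is whether a longer chain that keeps the double bond, or a carboxylic acid in place of the hydroxycarbamoyl end, would give a lower or a higher number in this assay than the chains seen so far. Among these compounds, it is also open how a nitro group on the outer ring would read on the saturated chain of compound 4, since it has been seen only on the ethenyl chain of compound 3.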